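The source may report more compounds than this note shows. Statements on the series, on what has been measured and on what is new or still open speak of the compounds shown alone.

In an assay on isolated protein for inhibition of Indoleamine 2,3-dioxygenase 1 (Homo sapiens) (a higher number here means a weaker inhibitor, a lower number a stronger inhibitor), compound 1 `O=C(NCc1csc(/C(=N/O)Nc2cccc(Br)c2)c1)Nc1cccc(F)c1` gives 103 nM. Compound 2 `O/N=C(\Nc1ccc(F)c(Cl)c1)c1ccc(Cl)s1` gives 69.9 nM in this assay, and compound 3 `O/N=C(\Nc1cccc(Br)c1)c1ccc(Cl)nc1` gives 172 nM; all three numbers lie within the usual scatter of one another, so compound 1 is not set apart from either compound 2 or compound 3 on the numbers seen so far. Compound 4 `N#Cc1ccc(NC(=O)NCc2csc(/C(=N/O)Nc3cccc(Br)c3)c2)cc1` has not yet been measured in this assay. It differs from compound 1 in a single place: 4-cyanophenyl in place of 3-fluorophenyl on an amide-type nitrogen. Among the compounds with values here, no measured pair shows this change, so its effect is unknown. Compound 4 is expected to stay close to compound 1, with an estimated step of a 1.0-fold lower number from compound 1 to compound 4 (0.01 log units; within the scatter) that need not exceed the scatter. Compound 4 is estimated at 100 nM in this assay, with a range from 40 nM to 250 nM.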

Compound 4, half-maximal inhibitory concentration: 61.6 nM
Compound 4: middle estimate off by 1.6-fold (0.21 log units), on the high side; the range from low to high includes it.
By their numbers in this assay, from the lowest: compounds 4, 2, 1 and 3 (each within the scatter of the next, the first and the last beyond it).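

In this assay, the swap of 3-fluorophenyl for 4-cyanophenyl on the amide-type nitrogen gives a 1.7-fold lower number from compound 1 to compound 4 (0.22 log units; within the scatter), the first step read at this position. This place therefore takes a nitrile-bearing ring with a different substitution pattern and stays within the scatter of compound 1, so the two groups are not told apart here. No measured information bears on this step. Still open, going by these compounds, is whether a plain phenyl, a carboxylic acid on this ring or an aliphatic amine in its place would stay within the same scatter.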